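The source may report more compounds than this note shows. Statements on the series, on what has been measured and on what is new or still open speak of the compounds shown alone.

Measured so far:
- compound 1 `CC(C)(C)c1cc(C(=O)NCCC2CCN(Cc3ccccc3)CC2)cc(C(C)(C)C)c1O` — 89200 nM
- compound 2 `CC(C)(C)c1cc(/C=C/C(=O)NC2CCN(Cc3ccccc3)CC2)cc(C(C)(C)C)c1O` — 33500 nM
- compound 3 `CC(C)(C)c1cc(/C=C/C(=O)NCCC2CCN(Cc3ccccc3F)CC2)cc(C(C)(C)C)c1O` — 7400 nM

In an assay on isolated protein for inhibition of Amine oxidase [flavin-containing] B (Homo sapiens), read by fluorescence, with stated times of 15 min and 20 min (on this read-out higher numbers stand for weaker inhibition and lower numbers for stronger inhibition), compound 3 gives the lowest number of the three. Compound 2 stands next, with a higher number, and compound 1 gives the highest; both gaps to compound 3 lie beyond the usual scatter of repeated measurements. No two of the measured compounds differ in a single place, so none of these gaps can be tied to one structural change.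

Compound 4 `CC(C)(C)c1cc(/C=C/C(=O)NCCC2CCN(Cc3ccc(F)cc3F)CC2)cc(C(C)(C)C)c1O` is the next compound in the series. It differs from compound 3 by fluoro in place of hydrogen on an aromatic carbon of the benzyl ring, taking 2-fluorobenzyl to 2,4-difluorobenzyl. Among the compounds with values here, nothing among the measured compounds shows what a second fluoro on this ring does; the three numbers hold no step of this kind.

The change is small, a single fluorine added to an already fluorinated benzyl group, and the expectation is a step from compound 3 to compound 4 of a 1.1-fold lower number from compound 3 to compound 4 (0.06 log units; within the scatter), not beyond the scatter in either direction. Compound 4 is therefore estimated at 6500 nM, with a range from 2500 nM to 17000 nM.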

Compound 4, half-maximal inhibitory concentration: 12500 nM
Beside the measured number, compound 4's estimate is 1.9-fold (0.28 log units) below it, and the stated range covers the measured number.
By their numbers in this assay, from the lowest: compounds 3 and 4 (each within the scatter of the next); then compound 2; then compound 1.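

In this assay the series gains its first step that can be read at a single place: a 1.7-fold higher number from compound 3 to compound 4 (0.23 log units; within the scatter). Fluoro in place of hydrogen on this aromatic carbon, para to a large group and meta to a fluoro group, therefore does not separate 2,4-difluorobenzyl from 2-fluorobenzyl on this read-out, and compound 3 and compound 4 stand together at the low end of the four numbers. This one step says that this position takes a fluoro with no change that can be told from repeat scatter, though it gives no explanation for that, and no supporting measurement here bears on the result.

From the compounds shown here alone, it remains open whether a larger group at this same position, such as chloro, methoxy or trifluoromethyl, would give a step beyond the scatter. Also open, going by these compounds, is what the 2-fluorobenzyl group contributes relative to plain benzyl on the same chain and amide, as compound 1 and compound 2 each differ from compound 3 in more than one place.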